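The source may hold more compounds than are shown below. What is called first, only, known or untested is meant among the compounds shown, and "the series" means these compounds.

Compound 2 `Nc1sc(-c2ccc(Cl)cc2)c(-c2ccc(Cl)cc2)c1C(=O)N1CCOCC1` carries the shared core of this series, and in a functional assay on PC-3 cells (Homo sapiens) for inhibition, read by sulforhodamine B assay, with a stated time of 72 h (a lower number here means a stronger inhibitor, a higher number a weaker inhibitor), compound 2 gives 11700 nM. Among the compounds shown, compound 2 is the only one with a single number in this assay. Compound 1 `Nc1sc(-c2ccc(Cl)cc2)c(-c2ccc(Cl)cc2)c1C(=O)Nc1ccccc1` reaches only a limit of this assay, > 50000 nM (the limit of > 50000 nM in this assay, at which 1 of the 3 values shown sits). Compound 3 `CS(=O)(=O)Nc1sc(-c2ccc(Cl)cc2)c(-c2ccc(Cl)cc2)c1C(=O)NC1CC1` has no result in this assay, its entry reading "not determined" (no result reported). Among the compounds with values here, the one measured step, an at least 4.2-fold lower number from compound 1 to compound 2 (0.63 log units; beyond the scatter), shows the amide substituent on the carbonyl carbon can move the number by a fair margin.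

Compound 4 `Nc1sc(-c2ccc(Cl)cc2)c(-c2ccc(Cl)cc2)c1C(=O)N1CCNCC1` differs from compound 2 in one place: piperazin-1-yl in place of morpholin-4-yl on a carbonyl carbon. Within the data shown here, no measured step touches this exchange directly; the step from compound 1 to compound 2 concerns a different pair of groups on the same carbonyl carbon, so it offers only the loose indication that this position is tolerant of change. Compound 4 is therefore expected to stay close to compound 2, with an estimated step of a 1.2-fold lower number from compound 2 to compound 4 (0.07 log units; within the scatter) in this assay. The estimate for compound 4 is 10000 nM, ranging from 3500 nM to 30000 nM.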

Compound 4, half-maximal inhibitory concentration: 2710 nM
Beside the measured number, compound 4's estimate is 3.7-fold (0.57 log units) above it; measured number outside the range, below it.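

Piperazin-1-yl in place of morpholin-4-yl on the carbonyl carbon gives a 4.3-fold lower number from compound 2 to compound 4 (0.64 log units; beyond the scatter) in this assay, so this position responds even to an exchange between two six-membered non-aromatic rings of equal heavy-atom count, the entering ring bearing a hydrogen-bond donor that morpholin-4-yl lacks. Taken from the anilino amide, the change to piperazin-1-yl gives an at least 18-fold lower number from compound 1 to compound 4 (1.26 log units; beyond the scatter), a larger move than either ring reached alone from morpholin-4-yl. Compound 1 stands only at a limit of the assay, so that step has no fixed upper end: the limit of > 50000 nM in this assay, at which 1 of the 4 values shown sits.

The compounds shown do not separate the ring nitrogen from its hydrogen, which a 4-methylpiperazin-1-yl or a piperidin-1-yl group on the same carbonyl carbon would address. They also leave open whether the exchange holds with anything other than the amino group on the shared core.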